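The compounds below may be only part of what the source reports. "The series", "measured", "known", "first", "only" and "open" are said of these compounds alone.

Three compounds have been measured in a functional assay on PC-3 cells (Homo sapiens) for inhibition, read by sulforhodamine B assay, with a stated time of 72 h; on this read-out higher numbers stand for weaker inhibition and lower numbers for stronger inhibition:

compound 1 `CC1CCN(C(=O)c2c(N)sc(-c3ccc(Cl)cc3)c2-c2ccc(Cl)cc2)CC1` gives 5750 nM;
compound 2 `Nc1sc(-c2ccc(Cl)cc2)c(-c2ccc(Cl)cc2)c1C(=O)NC1CCC(O)CC1` gives 5670 nM;
compound 3 `Nc1sc(-c2ccc(Cl)cc2)c(-c2ccc(Cl)cc2)c1C(=O)NCc1ccccc1` gives 31800 nM.

Compound 2 has the lowest number of the three in this assay, but the gap is small: a 1.0-fold lower number from compound 1 to compound 2 (0.01 log units; within the scatter), which lies within the scatter, so the two cannot be placed in order. Compound 3 is set apart: a 5.6-fold higher number from compound 2 to compound 3 (0.75 log units; beyond the scatter) and a 5.5-fold higher number from compound 1 to compound 3 (0.74 log units; beyond the scatter), both beyond the scatter.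

Compound 4 `Nc1sc(-c2ccc(Cl)cc2)c(-c2ccc(Cl)cc2)c1C(=O)NC1CCCC1` has not been measured. It differs from compound 2 in this way: cyclopentyl in place of 4-hydroxycyclohexyl on an amide-type nitrogen. The 4-hydroxycyclohexyl group leaves an amide-type nitrogen whose other neighbour is the carbonyl carbon, and a cyclopentyl group enters there.

Among the compounds with values here, no measured step swaps a ring of this kind for a cyclopentyl. What bears on it is that the two non-aromatic rings already tried, 4-methylpiperidin-1-yl and 4-hydroxycyclohexyl, give numbers within the scatter of each other, while only the benzyl of compound 3 moves the number beyond the scatter. Compound 4 is therefore expected to stay near compound 2, with a 1.2-fold higher number from compound 2 to compound 4 (0.09 log units; within the scatter) at most a small shift in this assay. Compound 4 is estimated at 7000 nM, in the range 3000 nM to 16000 nM.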

Compound 4, half-maximal inhibitory concentration: 21200 nM
Compound 4: the middle estimate sits 3.0-fold (0.48 log units) below what was measured; the whole stated range lies below it.
By their numbers in this assay, from the lowest: compounds 2 and 1 (each within the scatter of the next); then compounds 4 and 3 (each within the scatter of the next).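

In this assay, the result shows that a non-aromatic ring on this amide-type nitrogen does not by itself hold the number where compound 2 and compound 1 stand: there is a 3.7-fold higher number from compound 2 to compound 4 (0.57 log units; beyond the scatter) and a 3.7-fold higher number from compound 1 to compound 4 (0.57 log units; beyond the scatter), both beyond the scatter. With a 1.5-fold lower number from compound 3 to compound 4 (0.18 log units; within the scatter), which lies within the scatter, cyclopentyl and benzyl cannot be placed in order, so the earlier division between non-aromatic rings and benzyl no longer holds, and compound 4 is the compound that goes against it. The change from 4-hydroxycyclohexyl to cyclopentyl alters the ring size and removes the hydroxyl at once, and nothing available gives a reason for this step.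

The compounds shown leave open whether the ring size or the hydroxyl carries the step, and compound 1 keeps pace with compound 2 with no hydroxyl at all, so the hydroxyl cannot simply be read as required. A plain cyclohexyl on the same nitrogen would separate the two changes, and a 4-aminocyclohexyl or 4-methoxycyclohexyl would show how much depends on the hydroxyl itself.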